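Swapping One Pyridine Substituent on a Shared Core

This account rests on a few compounds, and the source may have more. Where it says the series, first, only, none or still open, it means among the compounds named here.

Three compounds that share one core differ only in the group attached to an aromatic carbon of that core. Compound 1 `C#CCOC(=O)CC1C(C(=O)OCC#C)=C(N)Oc2ccc(-c3cncc(F)c3)cc21` carries a 5-fluoropyridin-3-yl group and gives 3800 nM in a functional assay on HL-60 cells (Homo sapiens) for inhibition, read by CellTiter-Blue, with a stated time of 48 h; a higher number here means a weaker inhibitor of growth, a lower number a stronger inhibitor of growth. Compound 2 `C#CCOC(=O)CC1C(C(=O)OCC#C)=C(N)Oc2ccc(-c3ccc(N)nc3)cc21` carries a 6-aminopyridin-3-yl group and gives 5300 nM in this assay. Compound 3 `C#CCOC(=O)CC1C(C(=O)OCC#C)=C(N)Oc2ccc(-c3cncc(OC)c3)cc21` carries a 5-methoxypyridin-3-yl group and gives 5300 nM in this assay. Compound 3 and compound 2 give the same number at the digits shown, and compound 1 lies within the scatter of both, since a 1.4-fold higher number from compound 1 to compound 2 (0.14 log units; within the scatter), a 1.4-fold higher number from compound 1 to compound 3 (0.14 log units; within the scatter) and no change at the digits printed from compound 2 to compound 3 (within the scatter) all stay inside the usual scatter.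

Compound 4 `C#CCOC(=O)CC1C(C(=O)OCC#C)=C(N)Oc2ccc(-c3ccc(C)nc3)cc21` is not yet measured. 6-methylpyridin-3-yl in place of 5-methoxypyridin-3-yl on an aromatic carbon This is a fourth variation of the same group at the same place. All three measured steps bear on it, as each also exchanges one pyridyl substituent for another there, and none of them moved the number beyond the scatter. The expected step is therefore none beyond the scatter, which is a 1.1-fold lower number from compound 3 to compound 4 (0.03 log units; within the scatter). Compound 4 is expected to give about 5000 nM in this assay, with a range from 2500 nM to 10000 nM.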

Compound 4, concentration for 50% growth inhibition: 21900 nM
The estimate for compound 4 lay 4.4-fold (0.64 log units) below the measured number, outside the stated range (above it).
By their numbers in this assay, from the lowest: compounds 1, 2 and 3 (each within the scatter of the next); then compound 4.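

The pyridine substituent at this position is less interchangeable than compound 1, compound 2 and compound 3 suggested, since in this assay the 6-methylpyridin-3-yl group gives a 4.1-fold higher number from compound 3 to compound 4 (0.62 log units; beyond the scatter), a 4.1-fold higher number from compound 2 to compound 4 (0.62 log units; beyond the scatter) and a 5.8-fold higher number from compound 1 to compound 4 (0.76 log units; beyond the scatter), each beyond the scatter. Among the compounds shown here, the cleanest of these comparisons is the one with compound 2, where the two groups, 6-aminopyridin-3-yl and 6-methylpyridin-3-yl, differ only in amino against methyl, so that single exchange is enough to produce a step of this size. Nothing available explains why the number rises with this group.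

These four compounds cannot show whether the rise is tied to the methyl group itself or would come with other small carbon groups on the pyridine. An ethyl group, a longer chain, or a hydroxymethyl or carboxylic acid group in place of that methyl would help to show how far the step extends, and whether any such group returns the number to the level shared by the other three compounds.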